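The compounds below may be only part of what the source reports. "The series", "measured", "known", "first", "only" and "open" are said of these compounds alone.

Measured compounds:
- compound 1 `Cc1ccccc1Cn1cc(COc2ccc3c(=O)ccoc3c2)nn1` gives 15300 nM in a functional assay on HeLa cells (Homo sapiens) for cytotoxicity, read by MTT assay, with a stated time of 48 h; a higher number here means a weaker inhibitor, a lower number a stronger inhibitor.
- compound 2 `O=c1ccoc2cc(OCc3cn(Cc4cccc(Cl)c4)nn3)ccc12` reaches only the limit of this assay, > 100000 nM.
- compound 3 `O=c1ccoc2cc(OCc3cn(Cc4ccccc4Cl)nn3)ccc12` likewise reaches only the limit, > 100000 nM.

Compound 3 therefore stands without a number: its value is a limit, and one of the two other values is the same limit, as noted in the limit of > 100000 nM in this assay, at which 2 of the 3 values shown sit. For the measured compounds named here, the one readable step into compound 3 is an at least 6.5-fold higher number from compound 1 to compound 3 (0.81 log units; beyond the scatter), chloro in place of methyl on the aromatic carbon; the step that the two limits leave unreadable from compound 2 to compound 3 between the two limits cannot be sized.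

Compound 4 `O=c1ccoc2cc(OCc3cn(Cc4ccccc4Br)nn3)ccc12` differs from compound 3 by bromo in place of chloro on an aromatic carbon, read one bond further out as 2-chlorobenzyl to 2-bromobenzyl. Going by the values given here, no measured step exchanges one halogen for another, so none bears directly on it; the measured steps only show that compound 1 is the single compound with a readable number and that both chloro analogues sit at the limit. The step is expected to be a step that the limit leaves unreadable from compound 3 to compound 4, nothing beyond the scatter, with compound 4 most likely again reported as a limit. Compound 4 is estimated at 150000 nM, in the range 30000 nM to 600000 nM.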

Compound 4, half-maximal inhibitory concentration: 14500 nM
Compound 4: the middle estimate sits 10-fold (1.01 log units) above what was measured; measured number outside the range, below it.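

In this assay, the exchange of one halogen for another on this aromatic carbon, ortho to a large group, can now be read: bromo in place of chloro gives an at least 6.8-fold lower number from compound 3 to compound 4 (0.83 log units; beyond the scatter), and the 2-bromobenzyl compound also separates from the 3-chlorobenzyl compound, with an at least 6.8-fold lower number from compound 2 to compound 4 (0.83 log units; beyond the scatter). Bromo and methyl at this place do not separate, with a 1.1-fold lower number from compound 1 to compound 4 (0.02 log units; within the scatter), so among the three groups shown here, only chloro goes with the limit. Both larger steps are lower bounds only, because compound 2 and compound 3 give limits rather than numbers: the limit of > 100000 nM in this assay, at which 2 of the 4 values shown sit.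

Going by these compounds, what an iodo, a methoxy or an amine on this aromatic carbon would give stays open. On these data alone, the true distance between the chloro and bromo compounds also stays open.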